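The source may report more compounds than this note shows. Statements on the series, on what has been measured and on what is new or still open speak of the compounds shown alone.

Compound 1 `COc1cc(-c2cc(/C=C/C(=O)c3ccc(N)cc3)[nH]n2)cc(OC)c1OC` and compound 2 `COc1ccc(-c2cc(/C=C/C(=O)c3ccc(N)cc3)[nH]n2)cc1OC` share one core, while compound 3 `COc1cc(C(=O)/C=C/c2cc(-c3cc(OC)c(OC)c(OC)c3)n[nH]2)cc(OC)c1OC` is built on a different core; the difference between the two cores is not broken down here. In a functional assay on NCI-H522 cells (Homo sapiens) for cytotoxicity, read by sulforhodamine B assay, with a stated time of 48 h, tested at 0.01 uM (on this read-out lower numbers stand for a stronger effect and higher numbers for a weaker effect at the one concentration tested), compound 1 gives 92%. In this assay compound 2 gives 92%, and in this assay compound 3 gives 101%. The change from compound 1 to compound 2 is hydrogen in place of methoxy on an aromatic carbon, and the step it made was no change at the digits printed from compound 1 to compound 2 (within the scatter). Compound 4 `COc1ccc(-c2cc(/C=C/C(=O)c3cc(OC)c(OC)c(OC)c3)[nH]n2)cc1OC` has not yet been measured. It differs from compound 3 by hydrogen in place of methoxy on an aromatic carbon, which is the same change as that from compound 1 to compound 2, now made on the core of compound 3. For compound 4 the step in this assay is expected to be a number 1 percentage points lower from compound 3 to compound 4 (within the scatter), resting on the step of no change at the digits printed from compound 1 to compound 2 (within the scatter) seen with the same change on the other core. The read-out of compound 4 in this assay is therefore estimated at 100%, with a range expected from 88% to 110%.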

Compound 4, a percentage reported as activity, at one concentration (the size of the read-out at that concentration, not a potency): 89%
The estimate for compound 4 lay 11 percentage points above the measured number; measured number inside the range.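

In this assay, hydrogen in place of methoxy on an aromatic carbon of the core of compound 3 gives a number 12 percentage points lower from compound 3 to compound 4 (beyond the scatter), and a lower number here stands for a stronger effect. Set beside the same change on the core of compound 1, which gives no change at the digits printed from compound 1 to compound 2 (within the scatter), the two steps cannot be told apart: the same change on two cores in this assay, no change at the digits printed (within the scatter) from compound 1 to compound 2 and a number 12 percentage points lower (beyond the scatter) from compound 3 to compound 4, 12 percentage points apart, within the scatter of two such steps This does not show that the change carries over with a fixed size, nor that its outcome depends on the core, since each core offers a single pair and each read-out is the size of the effect at one concentration, not a potency.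

The compounds shown leave open whether the step seen here belongs to the loss of methoxy as such, as a hydroxyl, a fluorine or a longer ether chain such as ethoxy at the same place could tell. They also leave open how the pairs would compare at concentrations where the read-out falls further.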